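The source may hold more compounds than are shown below. What is called first, only, known or untested is meant among the compounds shown, and "the series" means these compounds.

Measured compounds:
compound 1 `COc1ccc2c(=O)c(/C=C/C(=O)Nc3ccc(Cl)cc3)coc2c1` — > 100000 nM
compound 2 `Cc1ccccc1NC(=O)/C=C/c1coc2cc(O)ccc2c1=O` — 9320 nM

In a functional assay (QGY7701 cells, Homo sapiens) for inhibition, read by MTT assay, with a stated time of 48 h (a higher number here means a weaker inhibitor, a lower number a stronger inhibitor), compound 1 returns only a limit, > 100000 nM, so its standing is bounded on one side and not pinned to a number. That reading sits at the limit of > 100000 nM in this assay, at which 1 of the 2 values shown sits. Compound 2 gives 9320 nM in this assay, a measured number. For the measured compounds named here, as no step between compound 1 and compound 2 is defined, the two values show only that compound 2 is recorded as a number while compound 1 is not pinned to one.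

Compound 3 `COc1ccc2c(=O)c(/C=C/C(=O)Nc3cccc(C)c3)coc2c1` has not yet been measured in this assay. It differs from compound 1 in 3-methylphenyl in place of 4-chlorophenyl on an amide-type nitrogen. Going by the values given here, with no measured step to lean on, the direction is open; a step of modest size, toward stronger inhibition or none beyond the scatter, is expected, and a second limit remains quite possible. Compound 3 is estimated at 60000 nM, within 15000 nM to 300000 nM. The expected step is an at least 1.6-fold lower number from compound 1 to compound 3 (0.22 log units; that floor lies within the scatter).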

Compound 3, half-maximal inhibitory concentration: > 100000 nM
Compound 3: a limit, no number; the forecaster's own chance of this, stated with the estimate: 50%; at least 1.6-fold (0.22 log units) between middle value and limit.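

In this assay compound 1 and compound 3 each return a limit and not a number, so no step can be read between them: the limit of > 100000 nM in this assay, at which 2 of the 3 values shown sit.

In this assay the compounds shown leave open how 3-methylphenyl and 4-chlorophenyl on an amide-type nitrogen compare.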